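Adding a methyl to the nitrogen of compound 2

This account rests on a few compounds, and the source may have more. Where it says the series, first, only, none or still open, it means among the compounds named here.

Compound 1 `COc1cc(/C=C/c2c[nH]c3ccccc23)cc(OC)c1OC` gives 3230 nM
Compound 2 `COc1cc(/C=C\c2c[nH]c3ccccc23)cc(OC)c1OC` gives 3230 nM

Against compound 1 in a functional assay on HL-60 cells (Homo sapiens) for inhibition (on this read-out lower numbers stand for stronger inhibition and higher numbers for weaker inhibition), compound 2 stands level at 3230 nM with nothing to separate them. Compound 3 `COc1cc(/C=C\c2cn(C)c3ccccc23)cc(OC)c1OC` differs from compound 2 by one change: methyl in place of hydrogen on an aromatic nitrogen. For the measured compounds named here, the only measured step (no change at the digits printed from compound 1 to compound 2 (within the scatter)) concerns the double bond and leaves that nitrogen untouched, so it offers no direct guide to this methyl. No shift beyond the scatter is therefore expected in this assay in either direction, though with wide uncertainty (estimated step: a 1.6-fold lower number from compound 2 to compound 3 (0.21 log units; within the scatter)). For compound 3 the estimated value is 2000 nM with an expected range from 400 nM to 10000 nM in this read-out.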

Compound 3, half-maximal inhibitory concentration: 3090 nM
Compound 3: the middle estimate sits 1.5-fold (0.19 log units) below what was measured, and the stated range covers the measured number.
By their numbers in this assay, from the lowest: compounds 3, 1 and 2 (each within the scatter of the next).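

In this assay methyl in place of hydrogen on the aromatic nitrogen gives a 1.0-fold lower number from compound 2 to compound 3 (0.02 log units; within the scatter) and so the hydrogen on that nitrogen is not needed to hold this level of inhibition. The position takes this one added carbon without a shift beyond the scatter. Nothing available explains why the number holds.

Open, as far as these compounds go, is whether a longer chain such as propyl, or an acetyl group, on this nitrogen would also leave the number in place. Also open, from the compounds shown here alone, is whether the same methyl would behave alike on compound 1, where the double bond is drawn E.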